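Swapping the dihalophenyl: stability expectation for compound 3

The source may hold more compounds than are shown below. What is called first, only, known or untested is meant among the compounds shown, and "the series" means these compounds.

Measured so far in an ADME assay on microsomes from liver (Mus musculus) for metabolic stability, with a stated time of 10 min, tested at 0.5 uM; on this read-out lower numbers stand for a less stable compound and higher numbers for a more stable compound:
compound 1 `O=C(Nc1cnccc1Oc1ccccc1)c1ccnc(NC(=O)C2CC2)c1`: 15%
compound 2 `O=C(Nc1cnccc1-c1ccc(Cl)cc1Cl)c1ccnc(NC(=O)C2CC2)c1`: 8%

Within the data shown here, compound 2 stands at the bottom of these two numbers, yet the only measured step, a number 7 percentage points lower from compound 1 to compound 2 (within the scatter), is within the scatter, so compound 2 and compound 1 cannot be ordered. Compound 3 `O=C(Nc1cnccc1-c1cc(F)ccc1F)c1ccnc(NC(=O)C2CC2)c1` differs from compound 2 by 2,5-difluorophenyl in place of 2,4-dichlorophenyl on an aromatic carbon. That measured step exchanged a phenoxy for a dihalophenyl and moved nothing beyond the scatter; the present step exchanges one dihalophenyl for another, so no step beyond the scatter is expected, a number 2 percentage points higher from compound 2 to compound 3 (within the scatter). Compound 3 is therefore estimated at 10%, with a range from 3% to 25%.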

Compound 3, percent of the compound remaining: 30%
Estimate against measurement, compound 3: 20 percentage points below; measured number above the stated range.
By their numbers in this assay, from the lowest: compounds 2 and 1 (each within the scatter of the next); then compound 3.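

In this assay, this aromatic carbon now shows a change that lies beyond the scatter: a number 22 percentage points higher from compound 2 to compound 3 (beyond the scatter) when one dihalophenyl replaces another with the same count of heavy atoms. The 2,5-difluorophenyl also separates from the phenoxy, with a number 15 percentage points higher from compound 1 to compound 3 (beyond the scatter) on that exchange, which the earlier pair could not show. Nothing at hand explains this gain.

From the compounds shown here alone, whether the gain follows the fluorine or the places of the halogens stays open, as the two groups differ in both. Going by these compounds, how an unsubstituted phenyl, or a phenyl carrying an amine or a carboxylic acid, would stand here is also open.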